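From Cyano to Aminomethyl: What Compound 3 May Show

This account rests on a few compounds, and the source may have more. Where it says the series, first, only, none or still open, it means among the compounds named here.

Measured so far:
compound 1, `N#C/C(=C\c1cccnc1)C(=O)O`: -39.8%
compound 2, `N#C/C(=C\c1ccoc1)C(=O)O`: 30.7%

Both numbers come from a functional assay on the whole organism (strain CD1) for inhibition, with Mus musculus as the target, with stated times of 15 min and 20 min, at a dose of 10 mg/kg by the subcutaneous route; on this read-out higher numbers stand for more inhibition at the one dose given (going by the name of the read-out) and lower numbers for less inhibition. Compound 2 stands highest of the two, and its nearest neighbour is compound 1, whose number lies far lower, a gap beyond the usual scatter of repeated measurements. No pair of these compounds differs in one place only, so no single structural step has yet been measured.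

Compound 3, `NC/C(=C\c1ccoc1)C(=O)O`, has not been measured. It is built from compound 2 by one change: aminomethyl in place of cyano on a double-bonded chain carbon bound to a carbonyl carbon and a double-bonded chain carbon. Among the measured compounds shown here, nothing among the measured compounds shows what such an exchange does in this assay, so no measured step can guide the expectation. With the cyano group gone and an aminomethyl group in its place, a downward step of moderate size is expected, though a result within the scatter of compound 2 cannot be ruled out; the expected step is a number 20.7 percentage points lower from compound 2 to compound 3 (beyond the scatter). For compound 3, the estimated result in this assay is 10%, expected to fall between -30% and 45%.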

Compound 3, a percentage reported as inhibition, in the whole organism at one dose (the size of the read-out at that dose, not a potency): -1.5%
For compound 3 the middle estimate is 11.5 percentage points above the measured one; low and high end bracket the measured number.
By their numbers in this assay, from the lowest: compound 1; then compound 3; then compound 2.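

Among the compounds shown here, this is the first single change that can be read in this assay: aminomethyl in place of cyano on a double-bonded chain carbon bound to a carbonyl carbon and a double-bonded chain carbon gives a number 32.2 percentage points lower from compound 2 to compound 3 (beyond the scatter), so this position is sensitive to the exchange. Both groups are made of 1 carbon and 1 nitrogen and carry no net charge, so the step comes with no change in those counts; what differs is that the triple bond leaves and 1 hydrogen-bond donor enters. No measurement shown here tells which of these differences matters, or why the read-out moves as it does.

On these data alone, what a hydroxymethyl group or a longer chain such as aminoethyl would do at this same place remains open. For the compounds shown here, it also remains open whether the exchange of cyano for aminomethyl would bring a step of similar size on the core of compound 1, whose ring differs from the one shared by compound 2 and compound 3.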